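Benzyl ether variation on a shared aminoether core

The source may report more compounds than this note shows. Statements on the series, on what has been measured and on what is new or still open speak of the compounds shown alone.

Of the compounds shown here, three of a shared core have been measured in a functional assay on SK-OV-3 cells (Homo sapiens) for inhibition, read by CCK-8 assay, with a stated time of 70 h; a lower number here means a stronger inhibitor, a higher number a weaker inhibitor. Compound 1 `O=[N+]([O-])c1cccc(COc2ccc(OCCOCCNC3CCCC3)cc2)c1` gives 15400 nM. Compound 2 `c1ccc(COc2ccc(OCCOCCNC3CCC3)cc2)cc1` gives 25000 nM, a number within the scatter of compound 1. Compound 3 `Clc1ccc(COc2ccc(OCCOCCNC3CCCCC3)cc2)cc1` gives 2650 nM, a lower number than compound 1 by a gap beyond the scatter. Compound 1 thus stands second highest of the three numbers. Compound 4 `COC(=O)c1ccc(COc2ccc(OCCOCCNC3CCCC3)cc2)cc1` differs from compound 1 in one place: 4-(methoxycarbonyl)phenyl in place of 3-nitrophenyl on a saturated chain carbon bound to an oxygen on an aromatic ring. Among the measured compounds shown here, no measured pair isolates this change, so its size is open. A step in this assay of modest size, in either direction and not clearly beyond the scatter, is expected. Compound 4 is estimated at 11000 nM, ranging from 3500 nM to 35000 nM. The expected step is a 1.4-fold lower number from compound 1 to compound 4 (0.15 log units; within the scatter).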

Compound 4, half-maximal inhibitory concentration: 6990 nM
Beside the measured number, compound 4's estimate is 1.6-fold (0.20 log units) above it; the range from low to high includes it.
By their numbers in this assay, from the lowest: compound 3; then compound 4; then compounds 1 and 2 (each within the scatter of the next).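

Among the compounds shown here, compound 1 and compound 4 are the first pair to differ in one place, so the aryl group on a saturated chain carbon bound to an oxygen on an aromatic ring can now be read alone in this assay. Placing 4-(methoxycarbonyl)phenyl there in place of 3-nitrophenyl gives a 2.2-fold lower number from compound 1 to compound 4 (0.34 log units; beyond the scatter), a modest response at this position. Nothing available gives a reason for this step.

The pair changes the group and its place on the ring together, so these two effects remain unseparated. From the compounds shown here alone, how a carboxylic acid or a primary amide would read in place of the methoxycarbonyl group stays open.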